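Trading one cyclohexyl for isobutyl at the assay limit

This account rests on a few compounds, and the source may have more. Where it says the series, first, only, none or still open, it means among the compounds named here.

In a toxicity assay on Hepa-1c1c7 cells (Mus musculus) for inhibition (a higher number here means a weaker inhibitor, a lower number a stronger inhibitor), compound 1 (`CCCCCC(O)C#CC#CC(O)CC(C)C`) gives 41000 nM as a measured number. Compound 2 (`OC(C#CC#CC(O)C1CCCCC1)C1CCCCC1`) gives > 50000 nM in this assay and this is a limit of the assay, not a number. Compound 3 (`CC(C)CC(O)C#CC#CC(O)C1CCCCC1`) carries isobutyl in place of cyclohexyl on a saturated chain carbon bound to an oxygen on a saturated carbon and a triple-bonded carbon. Going by the values given here, no measured step isolates this change. Among the compounds with values here, compound 1, which also carries isobutyl, gives 41000 nM and this is the only guide, so a small move toward stronger inhibition is expected in this assay at most. The estimated move is an at least 1.3-fold lower number from compound 2 to compound 3 (0.11 log units; that floor lies within the scatter) and another reading at the limit remains possible. For compound 3 the expected value is 38000 nM with an estimated range from 15000 nM to 70000 nM in this assay.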

Compound 3, half-maximal inhibitory concentration: > 50000 nM
Compound 3 was reported as a limit; the forecaster's own chance of this, stated with the estimate: 40%; middle value at least 1.3-fold (0.11 log units) from the limit.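

In this assay, isobutyl in place of cyclohexyl on a saturated chain carbon bound to an oxygen on a saturated carbon and a triple-bonded carbon did not yield a measured number: compound 3 gives > 50000 nM, which is a limit of the assay. The step between compound 2 and compound 3 cannot be read, as both sit at the same limit: the limit of > 50000 nM in this assay, at which 2 of the 3 values shown sit. With isobutyl kept, cyclohexyl in place of pentyl gives an at least 1.2-fold higher number from compound 1 to compound 3 (0.08 log units; that floor lies within the scatter), a floor that lies within the scatter, so this comparison shows no clear change.

The true size of that step remains hidden behind the limit. On these data alone, whether an amine or a longer chain at this place would give a measured number in this assay also remains open.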